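Dropping Two Methoxy Groups From a Triazole Anilide

A few compounds are considered here, and "the series" means these few. Any claim that something is new, unique, unknown or untested is made for them only; others in the source may bear on it.

Of the compounds shown here, two sharing one core have been tested in a functional assay on the whole organism (strain albino) for inhibition, with Rattus norvegicus as the target, read by paw edema, with stated times of 30 min and 3 h, at a dose of 0.28 mmol/kg by the oral route; on this read-out lower numbers stand for less inhibition and higher numbers for more inhibition at the one dose given (going by the name of the read-out). Compound 1, with structure `C=CCn1c(SCC(=O)Nc2ccc(/C(C)=N/O)cc2)nnc1-c1ccccc1`, carries an allyl group on a ring nitrogen and a phenyl on the neighbouring ring carbon; in this assay compound 1 gives 73%. Compound 2, with structure `CCn1c(SCC(=O)Nc2ccc(/C(C)=N/O)cc2)nnc1-c1ccc(OC)c(OC)c1`, carries an ethyl group instead and a 3,4-dimethoxyphenyl; in this assay compound 2 gives 66%. Compound 2 stands lowest of the two numbers, yet its gap to compound 1 lies within the scatter of repeated measurements, so the two values cannot be told apart.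

Compound 3, with structure `CCn1c(SCC(=O)Nc2ccc(/C(C)=N/O)cc2)nnc1-c1ccccc1`, is not yet measured. It differs from compound 2 in one place: phenyl in place of 3,4-dimethoxyphenyl on an aromatic carbon. Within the data shown here, compound 1 and compound 2 differ in two places and show no separable gap, so no measured step points in either direction. The step from compound 2 to compound 3 is therefore expected to be small, none beyond the scatter, namely a number 2 percentage points higher from compound 2 to compound 3 (within the scatter). In this assay compound 3 is estimated at 68%, with a range from 55% to 80%.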

Compound 3, a percentage reported as inhibition, in the whole organism at one dose (the size of the read-out at that dose, not a potency): 65%
For compound 3 the middle estimate is 3 percentage points above the measured one; the range from low to high includes it.
By their numbers in this assay, from the lowest: compounds 3, 2 and 1 (each within the scatter of the next).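

In this assay, phenyl in place of 3,4-dimethoxyphenyl on an aromatic carbon between two ring nitrogen atoms gives a number 1 percentage points lower from compound 2 to compound 3 (within the scatter), so at this position the read-out does not separate the two aryl groups. Among these compounds, this is the first comparison that isolates this position, since the earlier pair differed in two places at once. The same new compound also isolates the other place: methyl in place of vinyl on a saturated chain carbon bound to an aromatic nitrogen, which turns the allyl group into an ethyl group, gives a number 8 percentage points lower from compound 1 to compound 3 (within the scatter), so this change cannot be told apart from the scatter either, and nothing available bears on the reason for either result.

The compounds shown leave open whether a different kind of group on that aromatic carbon, such as a carboxylic acid or an amine on the phenyl ring, would move the number beyond the scatter, and whether a longer chain such as butyl on the ring nitrogen would do so. With a reading at only one dose, they also leave open how the potencies of these compounds compare.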